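A few compounds are considered here, and "the series" means these few. Any claim that something is new, unique, unknown or untested is made for them only; others in the source may bear on it.

Compound 1 (`CC(=C\c1ccccc1)/C=C1\CCC=CC1=O`) gives 4200 nM
Compound 2 (`O=C1C=CCC/C1=C\C=C\c1ccc(F)cc1`) gives 1900 nM
Compound 3 (`COc1ccccc1/C=C/C=C1\CCC=CC1=O`) gives 2500 nM

All three numbers were obtained in a functional assay on Bel7402/5-FU cells (Homo sapiens) for cytotoxicity, read by MTT assay, with a stated time of 72 h (on this read-out higher numbers stand for weaker inhibition and lower numbers for stronger inhibition), and they lie close together. Compound 2, at 1900 nM, sits at the low end of this small set, and compound 3, at 2500 nM, lies within the scatter of it. Compound 1, at 4200 nM, carries a higher number than compound 2, and that gap goes beyond the scatter.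

The next compound, compound 4 (`CC(=O)Oc1ccc(/C=C/C=C2\CCC=CC2=O)cc1`), has not yet been measured. It departs from compound 2 by one change: acetoxy in place of fluoro on an aromatic carbon, which in words is acetoxy in place of fluoro on an aromatic carbon, para to a large group. Among the measured compounds shown here, no measured pair in this set differs in one place only, so nothing here shows directly what this swap does. For the measured compounds named here, the only guide is the narrow spread of the three numbers, from compound 2 at 1900 nM to compound 1 at 4200 nM, and that spread argues against expecting a large move. The expected move in this assay is a 1.5-fold higher number from compound 2 to compound 4 (0.17 log units; within the scatter) and it is estimated to be small, toward weaker inhibition, and possibly no larger than the scatter. Compound 4 is therefore estimated at 2800 nM, with a range of 1200 nM to 6500 nM expected.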

Compound 4, half-maximal inhibitory concentration: 4100 nM
For compound 4 the middle estimate is 1.5-fold (0.17 log units) below the measured one; the measured number falls inside the stated range.
By their numbers in this assay, from the lowest: compounds 2, 3, 4 and 1 (each within the scatter of the next, the first and the last beyond it).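

Among the compounds shown here, the swap of acetoxy for fluoro on an aromatic carbon, para to a large group, gives the first reading of a single change in this set: in this assay it is a 2.2-fold higher number from compound 2 to compound 4 (0.33 log units; beyond the scatter). This shows that the position is not indifferent to the group it carries, as replacing fluoro, with 1 heavy atom and 0 hydrogen-bond acceptors, by acetoxy, with 4 heavy atoms and 2 hydrogen-bond acceptors, shifts the number toward weaker inhibition by a modest step that exceeds the scatter. No measurement available here accounts for this step, and the swap alone does not separate the contributions of the departing fluoro and the entering acetoxy.

The compounds shown leave open how other groups would fare at this same place, such as a hydroxyl, an amine or a chloro, and whether a smaller group than acetoxy would stay within the scatter of compound 2. For the compounds shown here, they also leave open whether the same swap would give a similar step on a different side chain, as this set holds only this one single-place comparison.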